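A few compounds are considered here, and "the series" means these few. Any claim that something is new, unique, unknown or untested is made for them only; others in the source may bear on it.

Going by the values given here, in a functional assay on NCI-H520 cells (Homo sapiens) (a higher number here means a weaker inhibitor of growth, a lower number a stronger inhibitor of growth), three compounds have numbers so far. Compound 1 `O=S(=O)(/C=C/c1ccc(O)cc1)Cc1ccc(Nc2ncnc3ccccc23)cc1` gives 100000 nM while compound 2 `O=S(=O)(/C=C/c1ccc(Cl)cc1)Cc1ccc(Nc2ncnc3ccc(Br)cc23)cc1` gives 13000 nM there. Compound 3 `O=S(=O)(/C=C/c1ccc(O)cc1)Cc1ccc(Nc2ncnc3ccc(Br)cc23)cc1` sits between them at 27000 nM as the second highest number of the three. Compound 4 `O=S(=O)(/C=C/c1ccc(F)cc1F)Cc1ccc(Nc2ncnc3ccc(Br)cc23)cc1` is still unmeasured, and its change from compound 3 is 2,4-difluorophenyl in place of 4-hydroxyphenyl on a double-bonded chain carbon bound to a double-bonded chain carbon with 2,4-difluorophenyl in place of 4-hydroxyphenyl on a double-bonded chain carbon bound to a double-bonded chain carbon. The nearest evidence is hydroxy in place of chloro on an aromatic carbon, which gave a 2.1-fold higher number from compound 2 to compound 3 (0.32 log units; beyond the scatter) and counts as modest. Among the compounds with values here, compound 4 likewise has halogen where compound 3 has hydroxy, though no fluorinated compound has been measured. The bromo step a 3.7-fold lower number from compound 1 to compound 3 (0.57 log units; beyond the scatter) is also modest, but it concerns a group that compound 3 and compound 4 both carry. In this assay a modest fall is therefore expected, estimated as a 2.1-fold lower number from compound 3 to compound 4 (0.32 log units; beyond the scatter) and reversing the chloro step in direction. The estimate for compound 4 is 13000 nM with an expected range from 5000 nM to 32000 nM.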

Compound 4, concentration for 50% growth inhibition: 100000 nM
Compound 4: the middle estimate sits 7.7-fold (0.89 log units) below what was measured, and the stated range ends below it.
By their numbers in this assay, from the lowest: compound 2; then compound 3; then compounds 1 and 4 (each within the scatter of the next).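

In this assay, 2,4-difluorophenyl in place of 4-hydroxyphenyl on a double-bonded chain carbon bound to a double-bonded chain carbon gives a 3.7-fold higher number from compound 3 to compound 4 (0.57 log units; beyond the scatter), and 2,4-difluorophenyl in place of 4-chlorophenyl at the same place gives a 7.7-fold higher number from compound 2 to compound 4 (0.89 log units; beyond the scatter). A halogen on this aromatic ring therefore does not by itself bring the lower number: among the three compounds that carry the bromo group, the 4-chlorophenyl and 2,4-difluorophenyl compounds lie on opposite sides of the 4-hydroxyphenyl compound. No measurement at hand accounts for this order.

The compounds shown leave open whether a 4-fluorophenyl or a 4-methoxyphenyl group at this place would fall nearer compound 2 or compound 4. They also leave open whether the same order of groups holds on the core of compound 1, without the bromo group.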